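The source may hold more compounds than are shown below. What is called first, only, known or untested is meant among the compounds shown, and "the series" means these compounds.

Measured so far:
Compound 1, `Cc1c(Nc2nc(N)c3c(C#N)c(N4CCC[C@H]4C)n(C)c3n2)cnn1[C@@H]1CCOC1`: 12 nM
Compound 2, `Cn1c(-c2cccc(F)c2F)c(C#N)c2c(N)ncnc21`: 159 nM
Compound 3, `Cc1cn(C)nc1Nc1cc2c(c(N)n1)c(C#N)c(N1CCC[C@H]1C)n2C`: 1290 nM

All three were tested in an assay on isolated protein for inhibition of Leucine-rich repeat serine/threonine-protein kinase 2 variant G2019S (Homo sapiens), read by TR-FRET and LanthaScreen, with stated times of 50 min and 30 min, in the presence of a further agent that is not named here; on this read-out lower numbers stand for stronger inhibition and higher numbers for weaker inhibition. Among them, compound 1 gives the lowest number, and since a lower number on this read-out stands for stronger inhibition, it is the strongest inhibitor of the set; compound 2 is the nearest of the others and compound 3 the furthest, with both gaps beyond the usual scatter. Compound 4, `Cc1c(Nc2nc(N)c3c(C#N)c(N4CCC[C@H]4C)n(C)c3n2)cnn1C`, has not yet been measured. It differs from compound 1 in one place: methyl in place of oxolan-3-yl on an aromatic nitrogen. Among the compounds with values here, no pair of measured compounds differing in a single place is available, so the size of this step cannot be read off from a comparison within this set. A modest weakening of inhibition is expected, that is a somewhat higher number, though a result within the scatter would not be surprising. The expected step is a 2.5-fold higher number from compound 1 to compound 4 (0.40 log units; beyond the scatter). Compound 4 is estimated at 30 nM, with a likely range from 8 nM to 120 nM.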

Compound 4, half-maximal inhibitory concentration: 43 nM
Compound 4: the middle estimate sits 1.4-fold (0.16 log units) below what was measured; low and high end bracket the measured number.
By their numbers in this assay, from the lowest: compound 1; then compound 4; then compound 2; then compound 3.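

In this assay, within the data shown here, putting methyl in place of oxolan-3-yl on this aromatic nitrogen gives a 3.6-fold higher number from compound 1 to compound 4 (0.55 log units; beyond the scatter), a modest step, and the only comparison here in which a single place changes. It shows that this position can lose a whole ring, with its oxygen and its defined stereocentre, at only a modest cost, as compound 4 still gives 43 nM. Nothing available here explains the size of this step.

A single step cannot separate the roles of the ring, its oxygen and its stereocentre. Cyclopentyl would keep a ring without the oxygen, the mirror-image form of oxolan-3-yl would test the stereocentre, and ethyl would show how inhibition responds to a small extension of the methyl.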